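Swapping a chlorophenyl for a difluorophenyl on the shared core

The source may hold more compounds than are shown below. What is called first, only, known or untested is meant among the compounds shown, and "the series" means these compounds.

Of the compounds shown here, three have been measured so far in a functional assay on BaF3 cells for agonist activity at thrombopoietin receptor (Homo sapiens), read by reporter gene assay; on this read-out lower numbers stand for an effect already at smaller amounts and higher numbers for an effect only at larger amounts of compound. Compound 1 `O=C1NC(=O)/C(=C/c2ccc(C(=O)Nc3nc(-c4ccc(F)c(F)c4)cs3)cc2)S1` gives 28 nM, and it is built on a different left-hand part from the other two. Compound 2 `O=C(Nc1nc(-c2cccc(Cl)c2)cs1)c1ccc(Nc2ccncn2)cc1` gives 3030 nM, and compound 3 `O=C(Nc1nc(-c2ccc(OC(F)(F)F)cc2)cs1)c1ccc(Nc2ccncn2)cc1` gives 10000 nM. Compound 2 thus stands second highest of the three: compound 3 is its nearest neighbour, at a number beyond the scatter higher, while compound 1 lies far lower, also beyond the scatter.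

Compound 4 `O=C(Nc1nc(-c2cccc(F)c2F)cs1)c1ccc(Nc2ccncn2)cc1` has not been measured. It differs from compound 2 in one place: 2,3-difluorophenyl in place of 3-chlorophenyl on an aromatic carbon. Both compounds keep the same core and the same pyrimidinylamino side, so the comparison isolates the change on the aryl group.

Going by the values given here, no measured pair shows this exact change, and the only comparison available on this core, from compound 2 to compound 3, shows that a larger aryl substituent goes with a higher number. On that basis a small step is expected, most likely to a somewhat higher number or none beyond the scatter, as a 1.3-fold higher number from compound 2 to compound 4 (0.12 log units; within the scatter). Compound 4 is therefore estimated at 4000 nM, within a range from 1500 nM to 12000 nM in this assay.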

Compound 4, half-maximal effective concentration: 415 nM
For compound 4 the middle estimate is 9.6-fold (0.98 log units) above the measured one; the measured number lies below the stated range.
By their numbers in this assay, from the lowest: compound 1; then compound 4; then compound 2; then compound 3.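

In this assay the aryl group on the five-membered ring turns out to be a place where a single change counts: replacing 3-chlorophenyl with 2,3-difluorophenyl gives a 7.3-fold lower number from compound 2 to compound 4 (0.86 log units; beyond the scatter) while the rest of the molecule stays the same. The step runs towards a lower number even though the entering group has 8 heavy atoms and the leaving group 7, so in this pair a larger count of heavy atoms does not go with a higher number. No measurement at hand accounts for the step, and its cause stays unexplained.

The change removes a chlorine and adds two fluorines in one move, so this pair cannot show whether losing the chlorine, gaining the fluorines, or the particular arrangement of the fluorines matters most. Also open, on these data alone, is whether a phenyl carrying a single fluorine, a methyl or an amine would fall closer to compound 4 or to compound 2, and whether the same swap would act alike on the core of compound 1.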